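The source may hold more compounds than are shown below. What is called first, only, known or untested is meant among the compounds shown, and "the series" means these compounds.

Measured so far in an ADME assay on HOS cells (Homo sapiens) for cytotoxicity; on this read-out higher numbers stand for lower toxicity in this test and lower numbers for higher toxicity in this test:
compound 1 `CN(Cc1nc2ccccc2n1CCCCN)C1CCCc2cccnc21`: 2900 nM
compound 2 `CN(Cc1nc2ccccc2n1CCCNC(=O)C(F)(F)F)C1CCCc2cccnc21`: 10400 nM
compound 3 `CN(Cc1nc2cccc(C(=O)NCCCCN)c2[nH]1)C1CCCc2cccnc21`: > 20000 nM

Compound 3 has no exact number: its entry is a limit, (the limit of > 20000 nM in this assay, at which 1 of the 3 values shown sits). Any step from compound 3 therefore starts from a limit and not from a measured point.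

Compound 4 `CN(Cc1nc2cccc(CCCN)c2[nH]1)C1CCCc2cccnc21` is still to be measured. It carries 3-aminopropyl in place of (4-aminobutyl)carbamoyl on an aromatic carbon.

For the measured compounds named here, the only measured step is a 3.6-fold higher number from compound 1 to compound 2 (0.55 log units; beyond the scatter). It is modest and beyond the scatter, but it lies on a saturated chain carbon, not on an aromatic carbon, so it bears on this change only loosely. Compound 1 gives 2900 nM with a free amine on its chain. Compound 3 also carries a free amine and goes against any link between that group and lower numbers.

Going by the size of a 3.6-fold higher number from compound 1 to compound 2 (0.55 log units; beyond the scatter), a modest move towards a lower number is expected, with a reading at the limit still possible. The expected change is an at least 2.2-fold lower number from compound 3 to compound 4 (0.34 log units; beyond the scatter). For compound 4 the estimate is 9000 nM, with an expected range of 3500 nM to 20000 nM.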

Compound 4, half-maximal cytotoxic concentration: 10000 nM
Beside the measured number, compound 4's estimate is 1.1-fold (0.05 log units) below it, and the stated range covers the measured number.
By their numbers in this assay, from the lowest: compound 1; then compounds 4 and 2 (each within the scatter of the next). At a limit, above all of these: compound 3.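

In this assay, the replacement of (4-aminobutyl)carbamoyl by 3-aminopropyl on this aromatic carbon gives an at least 2.0-fold lower number from compound 3 to compound 4 (0.30 log units; that floor lies within the scatter). With compound 4, this position has its first exact number, and a free amine on a chain at this carbon proves compatible with a reading under the limit, so that amine alone does not place a compound at the limit. The entry for compound 3 is a limit, which makes the step a floor and leaves its true size unknown: the limit of > 20000 nM in this assay, at which 1 of the 4 values shown sits.

The change removes the carbonyl and the amide hydrogen and also shortens the group, from 8 heavy atoms to 4, so the compounds shown do not tell these parts apart; a 4-aminobutyl chain with no carbonyl, or a 3-aminopropyl chain joined through a carboxamide, would help to separate them. Also open, as far as these compounds go, is whether the amine at the chain end matters at this position, which a hydroxyl group or a trifluoroacetamide on the 3-aminopropyl chain could test in this assay.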